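Acetyl to phenyl on compound 1: expected antiproliferative read-out

The source may report more compounds than this note shows. Statements on the series, on what has been measured and on what is new or still open speak of the compounds shown alone.

Measured so far in a functional assay on A-375 cells (Homo sapiens) for antiproliferative activity, read by trypan blue exclusion, with a stated time of 48 h, tested at 1 uM; on this read-out higher numbers stand for a weaker effect at the one concentration tested and lower numbers for a stronger effect:

compound 1 `CCCCCCC#Cc1ccc(S(=O)(=O)Nc2cccc(-c3csc(NC(C)=O)n3)c2)cc1` gives 40.7%
compound 2 `CC(=O)Nc1nc(-c2cccc(NS(=O)(=O)c3ccc(C#C[Si](C)(C)C)cc3)c2)cs1` gives 94.3%
compound 3 `CCCCCC/C=C\c1ccc(S(=O)(=O)Nc2cccc(-c3csc(NC(C)=O)n3)c2)cc1` gives 48.8%

Compound 1 has the lowest of the three numbers, with compound 3 within the scatter of it and compound 2 far above it. The large movements seen so far, a number 53.6 percentage points higher from compound 1 to compound 2 (beyond the scatter) and a number 45.5 percentage points lower from compound 2 to compound 3 (beyond the scatter), both sit on the tail attached to the six-membered ring next to the sulfonamide; the small one, a number 8.1 percentage points higher from compound 1 to compound 3 (within the scatter), also sits there.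

Compound 4 `CCCCCCC#Cc1ccc(S(=O)(=O)Nc2cccc(-c3csc(Nc4ccccc4)n3)c2)cc1` differs from compound 1 elsewhere: phenyl in place of acetyl on a nitrogen on an aromatic ring. Within the data shown here, no measured step touches the nitrogen on the aromatic ring, so the measured steps give no direct guide to this change. The working expectation is therefore a step of a number 4.3 percentage points higher from compound 1 to compound 4 (within the scatter) in this assay, that is none beyond the scatter, but with a wide range to reflect the absence of a precedent. Compound 4 is expected to give 45%, within 20% to 80%.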

Compound 4, a percentage reported as activity, at one concentration (the size of the read-out at that concentration, not a potency): 87.1%
Compound 4: middle estimate off by 42.1 percentage points, on the low side; the whole stated range lies below it.
By their numbers in this assay, from the lowest: compounds 1 and 3 (each within the scatter of the next); then compounds 4 and 2 (each within the scatter of the next).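

Acetamido to anilino is the first change shown away from the tail, and in this assay it gives a number 46.4 percentage points higher from compound 1 to compound 4 (beyond the scatter) with the tail of compound 1 kept. The place on a nitrogen on an aromatic ring is therefore not indifferent to its substituent: phenyl in place of acetyl weakens the effect at the one concentration tested, in a step of the large class also seen on the tail in a number 53.6 percentage points higher from compound 1 to compound 2 (beyond the scatter). No measurement shown bears on why the read-out moves at this place.

As far as these compounds go, it stays open whether the loss of acetyl or the arrival of phenyl drives the step, which a benzoyl group or a free amine on this nitrogen could separate. From the compounds shown here alone, it also stays open whether a propionyl group would hold the read-out near that of compound 1.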